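A few compounds are considered here, and "the series" means these few. Any claim that something is new, unique, unknown or untested is made for them only; others in the source may bear on it.

Compound 1 `CC(C)Cn1c(=O)n(C)c(=O)c2nc(SCCO)c(Cc3cccc4ccccc34)nc21` is the weakest of the three measured compounds in a functional assay on Raji cells (Homo sapiens) for inhibition, read by MTT assay, with a stated time of 96 h (on this read-out lower numbers stand for an effect already at smaller amounts and higher numbers for an effect only at larger amounts of compound), where compound 1 gives 2850 nM. Compound 2 `CC(C)Cn1c(=O)n(C)c(=O)c2nc(CCCCCO)c(Cc3cccc4ccccc34)nc21` gives 58 nM and compound 3 `CC(C)Cn1c(=O)n(C)c(=O)c2nc(CCCCCCO)c(Cc3cccc4ccccc34)nc21` gives 1690 nM. The step of a 49-fold lower number from compound 1 to compound 2 (1.69 log units; beyond the scatter) shows that a flexible hydroxyalkyl chain can bring a large gain, while a 1.7-fold lower number from compound 1 to compound 3 (0.23 log units; within the scatter) and a 29-fold higher number from compound 2 to compound 3 (1.46 log units; beyond the scatter) show how sharply that gain depends on chain length. Compound 4 `CC(C)Cn1c(=O)n(C)c(=O)c2nc(-c3[nH]nnc3CCCO)c(Cc3cccc4ccccc34)nc21` differs from compound 1 by 4-(3-hydroxypropyl)-1H-1,2,3-triazol-5-yl in place of (2-hydroxyethyl)sulfanyl on an aromatic carbon. Among the measured compounds shown here, no measured step introduces a ring, so the outcome is uncertain; the hydroxyl sits at a distance from the core comparable to compound 2, but the rigid ring gives no precedent. A moderate gain is therefore expected, a 5.7-fold lower number from compound 1 to compound 4 (0.76 log units; beyond the scatter), with compound 4 estimated at 500 nM (range 60 nM to 4000 nM).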

Compound 4, half-maximal effective concentration: 6020 nM
The estimate for compound 4 lay 12-fold (1.08 log units) below the measured number; the whole stated range lies below it.
By their numbers in this assay, from the lowest: compound 2; then compounds 3 and 1 (each within the scatter of the next); then compound 4.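

Putting 4-(3-hydroxypropyl)-1H-1,2,3-triazol-5-yl on this aromatic carbon brought no gain in this assay: the change gives a 2.1-fold higher number from compound 1 to compound 4 (0.32 log units; beyond the scatter), alongside a 3.6-fold higher number from compound 3 to compound 4 (0.55 log units; beyond the scatter) and a 100-fold higher number from compound 2 to compound 4 (2.02 log units; beyond the scatter), which makes compound 4 the weakest of the four. A five-membered aromatic ring carrying a hydroxyalkyl chain therefore did not reach the level of the 5-hydroxypentyl group in compound 2. Nothing available bears on this result. The compounds shown leave open how a 4-hydroxybutyl chain on the same ring would behave, and whether an amine could replace the hydroxy of the 5-hydroxypentyl group.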